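This account rests on a few compounds, and the source may have more. Where it says the series, first, only, none or still open, it means among the compounds named here.

Compound 1 `COc1ccc(/C=C/C(=O)NC(CCN(C)C)c2ccc(C)cc2)cc1` is examined in a functional assay on NIH3T3 cells for agonist activity at Urotensin-2 receptor (Homo sapiens), with a stated time of 5 days (a higher number here means a larger maximal response, a lower number a smaller maximal response), where compound 1 gives 79%. This is the highest of the two numbers at hand. The other measured compound, compound 2 `Cc1ccc(C(CCN(C)C)NC(=O)CCc2ccc(C(F)(F)F)cc2)cc1`, gives 60% in this assay, a value that lies beyond the usual scatter below that of compound 1. Among the compounds with values here, the two compounds differ in more than one place, so their values show only that compound 1 reaches the larger maximal response. The unmeasured compound 3 `COc1ccc(/C=C/C(=O)NC(CCN(C)C)c2ccc(Cl)cc2)cc1` keeps the core of compound 1 and differs from it in one place: chloro in place of methyl on an aromatic carbon. Within the data shown here, no pair of measured compounds differs in exactly one place, so there is no measured step to guide the expectation for this change. The change is a small one in structure, and for compound 3 the expected step from compound 1 is a number 3 percentage points lower from compound 1 to compound 3 (within the scatter), which is estimated to stay within the usual scatter, in no particular direction. Compound 3 is accordingly estimated at 76% in this assay, with a range from 58% to 94%.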

Compound 3, largest response reached (reported as efficacy), in percent of the reference or control that the assay uses: 99%
Estimate against measurement, compound 3: 23 percentage points below, outside the stated range (above it).
By their numbers in this assay, from the lowest: compound 2; then compound 1; then compound 3.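

Within the data shown here, the exchange of methyl for chloro on this aromatic carbon, para to a large group, gives the only measured step between compounds that differ in one place: in this assay it brings a number 20 percentage points higher from compound 1 to compound 3 (beyond the scatter) and so shows that this position is not indifferent to the group it carries. The change is small in what can be counted, with one heavy atom replacing one heavy atom, no hydrogen-bond donor or acceptor on either group and no net charge, yet the maximal response moves by more than the usual scatter. Nothing at hand bears on the reason for this step, which stays unexplained.

The compounds shown leave open whether the higher response belongs to chloro in particular or would also appear with a fluoro, a bromo or a nitrile group on the same aromatic carbon. They also leave open whether going from 4-methylphenyl to 4-chlorophenyl would bring a step of like size and direction in compound 2, which carries the same 4-methylphenyl group but a different amide part.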